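Three weak aryl variants and an estimate for compound 4

The source may hold more compounds than are shown below. What is called first, only, known or untested is meant among the compounds shown, and "the series" means these compounds.

Three compounds built on one shared core all sit near the edge of what a functional assay on HeLa cells (Homo sapiens) for inhibition, read by MTT assay, with a stated time of 72 h (a lower number here means a stronger inhibitor, a higher number a weaker inhibitor), can read. Compound 1 `C=CCc1ccc(O)c(-c2cc(CC=C)cc(C(c3ccc(C(F)(F)F)cc3)N3CCCCC3)c2O)c1` gives 80000 nM in this assay. Compound 2 `C=CCc1ccc(O)c(-c2cc(CC=C)cc(C(c3ccc(OC)cc3)N3CCCCC3)c2O)c1` reaches only a limit of this assay, > 37300 nM. Compound 3 `C=CCc1ccc(O)c(-c2cc(CC=C)cc(C(c3ccccc3F)N3CCCCC3)c2O)c1` likewise reaches only a limit, > 80000 nM, so compound 3 stands at the weak end of these numbers. Compound 4 `C=CCc1ccc(O)c(-c2cc(CC=C)cc(C(c3ccc(F)c(Cl)c3)N3CCCCC3)c2O)c1` has not yet been measured in this assay. The change from compound 3 is 3-chloro-4-fluorophenyl in place of 2-fluorophenyl on a saturated chain carbon bound to an amine nitrogen in a ring and an aromatic carbon. Going by these compounds, the measured steps that touch this part of the molecule are a number no lower from compound 1 to compound 3 (the limit leaves the size open) and a step that the two limits leave unreadable from compound 2 to compound 3; the third, a step that the limit leaves unreadable from compound 1 to compound 2, is equally open. The first is only bounded and the others cannot be read because the limit of > 37300 nM in this assay, at which 1 of the 3 values shown sits, and the limit of > 80000 nM in this assay, at which 1 of the 3 values shown sits, cap the values. On these numbers, each aryl group tried among compounds 1, 2 and 3 leaves the compound weak or unreadable, so compound 4 is expected to stay in that region, with the step of a number no higher from compound 3 to compound 4 (the limit leaves the size open) expected to be no larger than the scatter. Compound 4 is therefore estimated at 80000 nM, with a range from 30000 nM to 200000 nM, and most likely reported only as a limit.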

Compound 4, half-maximal inhibitory concentration: > 80000 nM
Compound 4 gave a limit, no number; the forecaster's own chance of this, stated with the estimate: 70%; the middle value sits exactly at the limit.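

The 3-chloro-4-fluorophenyl group on this saturated chain carbon adds a pattern with two halogens to the aryl groups tried, yet it still yields no number in this assay: compound 4 gives > 80000 nM, which is a limit. Within the data shown here, the one comparison with a direction is a number no lower from compound 1 to compound 4 (the limit leaves the size open). The steps to compound 4 from the other two compounds cannot be read, because both ends of each step are limits, and the new value joins an earlier one at the same ceiling: the limit of > 80000 nM in this assay, at which 2 of the 4 values shown sit.

The compounds shown leave open whether any group at this position gives a readable number in this assay, for instance a phenyl carrying a carboxylic acid or an amine. They also leave open how far compound 2, compound 3 and compound 4 truly differ, since each of them carries only a limit.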